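Hydrogen in Place of Acetyl, Tried on Two Cores

A few compounds are considered here, and "the series" means these few. Any claim that something is new, unique, unknown or untested is made for them only; others in the source may bear on it.

Compound 1 `COc1ccc(C2=C(c3cc(OC)c(OC)c(OC)c3)C(=O)C(OC(C)=O)C2)cc1OC(C)C`: in an ADME assay on HEK293 cells (Homo sapiens) for cytotoxicity, read by MTT assay, with a stated time of 72 h (on this read-out higher numbers stand for weaker inhibition and lower numbers for stronger inhibition), compound 1 gives > 100 ug/mL, a limit of the assay and not a number.
Compound 2 `CC(=O)OC1C/C(=N/O)C(c2ccccc2)=C1c1ccccc1`: in this assay compound 2 gives 92.3 ug/mL.
Compound 3 `COc1ccc(C2=C(c3cc(OC)c(OC)c(OC)c3)C(=O)C(O)C2)cc1OC(C)C`: in this assay compound 3 gives > 100 ug/mL, again a limit of the assay.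

Compound 3 differs from compound 1 by a single change, (hydrogen in place of acetyl on an oxygen on a saturated carbon). The size of the step that the two limits leave unreadable from compound 1 to compound 3 cannot be read, due to the limit of > 100 ug/mL in this assay, at which 2 of the 3 values shown sit. Compound 4 `O/N=C1/CC(O)C(c2ccccc2)=C1c1ccccc1`, not yet measured, differs from compound 2 by the same change at the same place, (hydrogen in place of acetyl on an oxygen on a saturated carbon). The difference between the two cores of compound 1 and compound 2 is not broken down here. Because the step that the two limits leave unreadable from compound 1 to compound 3 has no readable size, the expectation for compound 4 rests on compound 2 alone, whose value 92.3 ug/mL is the only number shown. Compound 4 is therefore expected at about 100 ug/mL, somewhere between 50 ug/mL and 200 ug/mL. The expected step of a 1.1-fold higher number from compound 2 to compound 4 (0.03 log units; within the scatter) is estimated to be small.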

Compound 4, half-maximal inhibitory concentration: > 100 ug/mL
Compound 4 ended at the assay's limit; the forecaster's own chance of this, stated with the estimate: 50%; the middle value lies on the limit itself.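

In this assay, the change from acetoxy to hydroxy on the core of compound 2 gives an at least 1.0-fold higher number from compound 2 to compound 4 (0.03 log units; that floor lies within the scatter). This floor lies within the usual scatter, so the step shows no clear change, though its true size could be larger. The matching step on the core of compound 1 cannot be read, so the change cannot be compared across the two cores, and nothing shows that it carries over with the same size, the reason being that both compound 3 and compound 4 end at a limit: the limit of > 100 ug/mL in this assay, at which 3 of the 4 values shown sit.

The compounds shown leave open how far past that limit compound 3 and compound 4 lie. They also leave open how an amine or a longer ester chain in place of the hydroxy would read in this assay.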